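Methyl in Place of Chloro on a Core Without a Reading

The source may report more compounds than this note shows. Statements on the series, on what has been measured and on what is new or still open speak of the compounds shown alone.

Compound 1, `C=CC1=C(C(=O)NCc2ccc(Cl)cc2)C(c2ccc(OC)c(OC)c2)OC1`, was tested in a functional assay on SW480 cells (Homo sapiens) for cytotoxicity, read by MTT assay, with a stated time of 24 h; a lower number here means a stronger inhibitor, a higher number a weaker inhibitor. In this assay compound 1 gives > 100000 nM, which is a limit of the assay and not a number. Two companions share the core. Compound 2, `C=CC1=C(C(=O)NCc2ccc(Cl)cc2)C(c2ccc(OC)cc2)OC1`, carries hydrogen in place of methoxy on an aromatic carbon; in this assay compound 2 gives > 100000 nM, again a limit. Compound 3, `C=CC1=C(C(=O)NCCCCC)C(c2ccc(F)cc2)OC1`, in this assay gives > 100000 nM, likewise a limit. Among the compounds with values here, the one step that can be drawn, a step that the two limits leave unreadable from compound 1 to compound 2, is consequently of unreadable size. Compound 1 thus stands only at a limit, and both companions sit at the same limit, as the limit of > 100000 nM in this assay, at which 3 of the 3 values shown sit, records.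

Compound 4, `C=CC1=C(C(=O)NCc2ccc(C)cc2)C(c2ccc(OC)c(OC)c2)OC1`, has not been measured. It differs from compound 1 by methyl in place of chloro on an aromatic carbon. Within the data shown here, no measured step bears on methyl in place of chloro on an aromatic carbon; the only step on record is unreadable, and every value shown sits at the limit described in the limit of > 100000 nM in this assay, at which 3 of the 3 values shown sit. The expectation for compound 4 is accordingly no readable step, with this assay most likely reporting a limit once more. Compound 4 is estimated at 150000 nM, within 40000 nM to 600000 nM, an expected step that the limit leaves unreadable from compound 1 to compound 4 that stays within the scatter.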

Compound 4, half-maximal inhibitory concentration: > 100000 nM
Compound 4 gave a limit, no number (the forecaster's own chance of this, stated with the estimate: 80%); the middle value lies beyond the limit too.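

In this assay compound 4 gives > 100000 nM, which is a limit and not a number. Compound 1 also stands only at a limit, so no step can be read between compound 1 and compound 4. The compounds shown leave open whether methyl in place of chloro changes anything on this core, as all of them share one ceiling: the limit of > 100000 nM in this assay, at which 4 of the 4 values shown sit.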